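This account rests on a few compounds, and the source may have more. Where it says the series, first, only, none or still open, it means among the compounds named here.

In a functional assay on SF-295 cells (Homo sapiens) for inhibition, read by sulforhodamine B assay, with a stated time of 48 h (on this read-out higher numbers stand for weaker inhibition of growth and lower numbers for stronger inhibition of growth), compound 2 `Nc1cc(N)c2nc(-c3ccccc3)c(NCc3ccc(F)cc3)nc2c1` gives 13500 nM, the lowest of the two numbers recorded, while compound 1 `COc1ccc(CNc2nc3cc(N)cc(N)c3nc2-c2ccccc2)cc1OC` gives 28200 nM. Within the data shown here, the single measured step, a 2.1-fold lower number from compound 1 to compound 2 (0.32 log units; beyond the scatter), exchanges 3,4-dimethoxyphenyl for 4-fluorophenyl on the benzylic carbon attached to the ring nitrogen. Compound 3 `COc1ccc(CNc2nc3cc(N)cc(N)c3nc2-c2ccccc2)cc1` partly reverses this exchange: methoxy in place of fluoro on an aromatic carbon. Because a 2.1-fold lower number from compound 1 to compound 2 (0.32 log units; beyond the scatter) was modest, the expected step of a 1.5-fold higher number from compound 2 to compound 3 (0.17 log units; within the scatter) is also modest and toward a higher number, moving back toward compound 1. Compound 3 is therefore estimated at 20000 nM, with a range of 8000 nM to 50000 nM.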

Compound 3, concentration for total growth inhibition: 32400 nM
Compound 3: middle estimate off by 1.6-fold (0.21 log units), on the low side; measured number inside the range.
By their numbers in this assay, from the lowest: compound 2; then compounds 1 and 3 (each within the scatter of the next).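

In this assay, methoxy in place of fluoro on the aromatic carbon para to a large group is enough on its own for a modest step (a 2.4-fold higher number from compound 2 to compound 3 (0.38 log units; beyond the scatter)). Hydrogen in place of methoxy on an aromatic carbon stays within the scatter (a 1.1-fold higher number from compound 1 to compound 3 (0.06 log units; within the scatter)), so the extra methoxy of compound 1 adds no measurable difference here. No measured evidence accounts for either step.

The compounds shown leave open how chloro, hydroxyl or an amine would read at this para carbon. They also leave open whether hydrogen there would stand nearer compound 2 or compound 3.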